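A few compounds are considered here, and "the series" means these few. Any claim that something is new, unique, unknown or untested is made for them only; others in the source may bear on it.

Measured in an in vitro ADME assay on microsomes from liver (Homo sapiens) for pharmacokinetics, read by LC-MS, with a stated time of 10 min, tested at 1 uM; on this read-out lower numbers stand for slow clearance and higher numbers for fast clearance:
Compound 1 `CN1C[C@H](C(=O)Nc2ccccc2F)[C@@H](c2ccc(/C=C/C(=O)Nc3ccccc3N)cc2)C1`: 10 mL/min/kg
Compound 2 `CN1C[C@H](C(=O)Nc2ccc(Cl)c(Cl)c2)[C@@H](c2ccc(/C=C/C(=O)Nc3ccccc3N)cc2)C1`: 14 mL/min/kg
Compound 3 `Cc1ccc(NC(=O)[C@H]2CN(C)C[C@@H]2c2ccc(/C=C/C(=O)Nc3ccccc3N)cc2)cn1`: 8 mL/min/kg

Compound 3, at 8 mL/min/kg, lies within the scatter of both other compounds. Compound 4 `CC(C)NC(=O)[C@H]1CN(C)C[C@@H]1c1ccc(/C=C/C(=O)Nc2ccccc2N)cc1` differs from it by isopropyl in place of 6-methylpyridin-3-yl on an amide-type nitrogen. Among the compounds with values here, three measured steps bear on this place: a 1.4-fold higher number from compound 1 to compound 2 (0.15 log units; within the scatter), a 1.3-fold lower number from compound 1 to compound 3 (0.10 log units; within the scatter) and a 1.8-fold lower number from compound 2 to compound 3 (0.24 log units; within the scatter). Within the data shown here, all stay within the scatter, but each exchanges one aromatic group for another, and no measured compound carries isopropyl there. No change beyond the scatter is therefore expected in this assay, although the support is thin. The expected step is a 1.1-fold higher number from compound 3 to compound 4 (0.05 log units; within the scatter). For compound 4 the estimate is 9 mL/min/kg, with an expected range of 5 mL/min/kg to 16 mL/min/kg.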

Compound 4, clearance: 8 mL/min/kg
The estimate for compound 4 lay 1.1-fold (0.05 log units) above the measured number; the measured number falls inside the stated range.
By their numbers in this assay, from the lowest: compounds 3, 4, 1 and 2 (each within the scatter of the next).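

With isopropyl on the amide-type nitrogen, this assay gains its first comparison with a group that has no ring: there is no change at the digits printed from compound 3 to compound 4 (within the scatter) and a 1.8-fold lower number from compound 2 to compound 4 (0.24 log units; within the scatter) and also a 1.3-fold lower number from compound 1 to compound 4 (0.10 log units; within the scatter) in this series. Among these four compounds, replacing each aromatic group with isopropyl therefore leaves the number within the scatter, so a ring at this place is not required for a value in this range. No available evidence explains this result.

The compounds shown leave open whether a primary amine, a carboxylic acid or a longer alkyl chain on this nitrogen would also stay within the scatter.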